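The source may report more compounds than this note shows. Statements on the series, on what has been measured and on what is new or still open speak of the compounds shown alone.

Compound 1 `O=C(Nc1cccc(-n2cc(-c3ccncc3)c(-c3ccc(Cl)c(O)c3)n2)c1)Nc1ccc(Cl)c(Cl)c1`: in a functional assay on HOP-62 cells (Homo sapiens) for inhibition, read by sulforhodamine B assay, with a stated time of 48 h (on this read-out lower numbers stand for stronger inhibition of growth and higher numbers for weaker inhibition of growth), compound 1 gives 17600 nM.
Compound 2 `COc1cc(-c2nn(-c3cccc(NC(=O)c4ccc(Cl)c(C(F)(F)F)c4)c3)cc2-c2ccncc2)ccc1Cl`: in this assay compound 2 gives only a limit, > 32500 nM.
Compound 3 `COc1cc(-c2nn(-c3cccc(NC(=O)c4cccc(C(F)(F)F)c4)c3)cc2-c2ccncc2)ccc1Cl`: in this assay compound 3 gives only a limit, > 50000 nM.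

Compound 3 therefore stands at a limit and not at a number, and one further value among the three measured is also a limit. Among the measured compounds shown here, the only single-place step among the measured compounds, a step that the two limits leave unreadable from compound 2 to compound 3, cannot be read because the limit of > 32500 nM in this assay, at which 1 of the 3 values shown sits, and the limit of > 50000 nM in this assay, at which 1 of the 3 values shown sits, cap both of its ends.

Compound 4 `COc1cc(-c2nn(-c3cccc(NC(=O)Nc4cccc(C(F)(F)F)c4)c3)cc2-c2ccncc2)ccc1Cl` differs from compound 3 by (3-(trifluoromethyl)phenyl)amino in place of 3-(trifluoromethyl)phenyl on a carbonyl carbon. For the measured compounds named here, no measured step carries this change. Going by the values given here, compound 1 does give a number, but its structure differs from compound 4 in more than one place, so its value shows only that a number can be reached. With compound 3 at a limit, neither direction nor size of the step can be drawn from the data; the estimate an at least 1.6-fold lower number from compound 3 to compound 4 (0.22 log units; that floor lies within the scatter) is therefore expected to be small. Compound 4 is estimated at 30000 nM, with a range from 10000 nM to 90000 nM.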

Compound 4, concentration for total growth inhibition: 4070 nM
For compound 4 the middle estimate is 7.4-fold (0.87 log units) above the measured one; measured number outside the range, below it.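

In this assay, among the compounds shown here, the carbonyl carbon gives the first readable single-place step: (3-(trifluoromethyl)phenyl)amino in place of 3-(trifluoromethyl)phenyl gives an at least 12-fold lower number from compound 3 to compound 4 (1.08 log units; beyond the scatter). The same place, with (3-(trifluoromethyl)phenyl)amino in place of 4-chloro-3-(trifluoromethyl)phenyl, gives an at least 7.9-fold lower number from compound 2 to compound 4 (0.90 log units; beyond the scatter). Both steps are floors and not full sizes, as each starts from a limit and not a number: the limit of > 50000 nM in this assay, at which 1 of the 4 values shown sits.

From the compounds shown here alone, the step between the two limits still cannot be read, so the effect of the chloro group on the ring remains unknown here. Also open, going by these compounds, is whether the gain depends on the amide hydrogen of the entering amino group, which an N-methylamino or an oxygen link, as in a carbamate, at the same carbonyl carbon would test.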